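This account rests on a few compounds, and the source may have more. Where it says the series, first, only, none or still open, it means among the compounds named here.

Working notes on the series. In a functional assay on SK-MEL-2 cells (Homo sapiens) for inhibition, read by sulforhodamine B assay, with a stated time of 48 h (a lower number here means a stronger inhibitor of growth, a higher number a weaker inhibitor of growth), compound 1 `COc1cc(-c2nn(-c3cccc(NC(=O)Nc4cc(C(F)(F)F)cc(C(F)(F)F)c4)c3)cc2-c2ccncc2)ccc1Cl` gives 1020 nM, compound 2 `COc1cc(-c2nn(-c3cccc(NC(=O)Nc4ccc(Cl)c(Cl)c4)c3)cc2-c2ccncc2)ccc1Cl` gives 1140 nM and compound 3 `COc1cc(-c2nn(-c3cccc(NC(=O)Nc4cccc(C(F)(F)F)c4)c3)cc2-c2ccncc2)ccc1Cl` gives 970 nM. These three values lie within the scatter of one another, so compound 3 is not separated from either neighbour.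

Compound 4 `COc1cc(-c2nn(-c3cccc(NC(=O)c4ccccc4)c3)cc2-c2ccncc2)ccc1Cl` has not been measured. Its difference from compound 3 is phenyl in place of (3-(trifluoromethyl)phenyl)amino on a carbonyl carbon.

Going by the values given here, two measured steps bear on this, and only in part: a 1.1-fold lower number from compound 1 to compound 3 (0.02 log units; within the scatter) and a 1.2-fold lower number from compound 2 to compound 3 (0.07 log units; within the scatter). Both lie within the scatter, and both alter only the substitution of the aryl group. Among the compounds with values here, neither removes the amino link, so the series holds no measured step of the same kind as this change. The flatness across compounds 1, 2 and 3 therefore gives only a weak guide, and the expectation carries a wide range.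

The expected step is a 1.6-fold higher number from compound 3 to compound 4 (0.22 log units; within the scatter), a small estimated move towards a higher number in this assay that does not clearly leave the scatter. For compound 4 the estimated value is 1600 nM, with an expected range from 550 nM to 5000 nM.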

Compound 4, concentration for 50% growth inhibition: 389 nM
Estimate against measurement, compound 4: 4.1-fold (0.61 log units) above, and the stated range ends above it.
By their numbers in this assay, from the lowest: compound 4; then compounds 3, 1 and 2 (each within the scatter of the next).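

In this assay, phenyl in place of (3-(trifluoromethyl)phenyl)amino on the carbonyl carbon gives a 2.5-fold lower number from compound 3 to compound 4 (0.40 log units; beyond the scatter), and phenyl in place of (3,4-dichlorophenyl)amino at the same place gives a 2.9-fold lower number from compound 2 to compound 4 (0.47 log units; beyond the scatter); both steps are modest but lie beyond the scatter. Going by these compounds alone, the earlier steps changed only the substitution of the aryl group and stayed within the scatter, so these are the first steps to show that the group on this carbonyl carbon can shift the number, and that the amino link is not needed for growth inhibition at this level. No measurement on hand explains the shift.

The change removes the amino link and the aryl substituents together, so the compounds shown cannot divide the step between them; an unsubstituted phenylamino group on the carbonyl carbon would separate the two. As far as these compounds go, it also remains open whether the aromatic ring is needed at this place, or whether a methyl group, a longer alkyl chain or a morpholine on the carbonyl carbon would hold or extend the step.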